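This account rests on a few compounds, and the source may have more. Where it says the series, first, only, none or still open, it means among the compounds named here.

The measured compounds are compound 1, `COc1ccc(C(=O)CCc2ccc(OC)cc2OC)c(O)c1`, with 83.4%, and compound 2, `COc1ccc(C(=O)CCc2ccc(OC)c(OC)c2)c(O)c1`, with 67.5%.

Both numbers come from an ADME assay on RAW264.7 cells (Mus musculus) for cytotoxicity, read by MTT assay, with a stated time of 24 h, tested at 10 ug/mL; on this read-out lower numbers stand for a stronger effect and higher numbers for a weaker effect at the one concentration tested. Compound 2 stands lowest of the two; its nearest neighbour is compound 1, whose number is higher by a margin beyond the scatter of this assay. The unmeasured compound 3, `COc1ccc(CCC(=O)c2ccc(OC)cc2O)cc1`, differs from compound 2 in one place: hydrogen in place of methoxy on an aromatic carbon. A methoxy leaves and a hydrogen enters on an aromatic carbon of the six-membered aromatic ring of carbon only, ortho to a methoxy group. Going by the values given here, no step between measured compounds shows what such a change does here, so the direction is open. The step expected is small, a number 5.5 percentage points higher from compound 2 to compound 3 (within the scatter), within or only just beyond the scatter. Compound 3 is therefore expected to give 73%, with a range from 55% to 91%.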

Compound 3, a percentage reported as activity, at one concentration (the size of the read-out at that concentration, not a potency): 88%
For compound 3 the middle estimate is 15 percentage points below the measured one; measured number inside the range.
By their numbers in this assay, from the lowest: compound 2; then compounds 1 and 3 (each within the scatter of the next).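

In this assay, going by these compounds alone, this carbon proves sensitive to the exchange: with hydrogen in place of the methoxy that stands ortho to a methoxy group and meta to a large group, the result is a number 20.5 percentage points higher from compound 2 to compound 3 (beyond the scatter), the first reading of this change. The same kind of exchange at another carbon of that ring gives a number 4.6 percentage points higher from compound 1 to compound 3 (within the scatter), so the size of the step seen at one carbon does not carry over to the other. Nothing available explains why the two steps differ.

Going by these compounds, it remains open whether an amine, a hydroxyl, a fluorine or an ethoxy group on this carbon would read like the methoxy of compound 2 or like the hydrogen of compound 3. On these data alone, whether the step holds at other concentrations also remains open.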